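Swapping chloro for trifluoromethyl on the urea aryl ring

The compounds below may be only part of what the source reports. "The series", "measured", "known", "first", "only" and "open" are said of these compounds alone.

Compound 1, `COc1cc(-c2nn(-c3cccc(NC(=O)Nc4ccc(Cl)c(Cl)c4)c3)cc2-c2ccncc2)ccc1Cl`: 1240 nM
Compound 2, `O=C(Nc1cccc(-n2cc(-c3ccncc3)c(-c3ccc(Cl)c(O)c3)n2)c1)Nc1ccc(Cl)c(Cl)c1`: 4890 nM
Compound 3, `O=C(Nc1cccc(-n2cc(-c3ccncc3)c(-c3ccc(Cl)c(O)c3)n2)c1)Nc1cc(C(F)(F)F)cc(C(F)(F)F)c1`: 746 nM

Of the compounds shown here, three built on one shared core have been measured in a functional assay on HT-29 cells (Homo sapiens) for inhibition, read by sulforhodamine B assay, with a stated time of 48 h; a lower number here means a stronger inhibitor of growth, a higher number a weaker inhibitor of growth. Compound 1 stands second highest of the three numbers: compound 3 sits nearest, with a number lower by an amount within the scatter, and compound 2 furthest, with a number higher beyond it. Going by the values given here, the only single-place step among them, a 3.9-fold higher number from compound 1 to compound 2 (0.60 log units; beyond the scatter), concerns the other end of the molecule.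

Compound 4, `COc1cc(-c2nn(-c3cccc(NC(=O)Nc4ccc(Cl)c(C(F)(F)F)c4)c3)cc2-c2ccncc2)ccc1Cl`, differs from compound 1 by trifluoromethyl in place of chloro on an aromatic carbon. Among the compounds with values here, no measured step alters just this spot. Compounds 2 and 3 differ on this same ring, but at two positions at once: in this assay compound 2 gives 4890 nM and compound 3 gives 746 nM, so the pair carrying trifluoromethyls shows the lower number, without that being a one-place step. Compound 4 is therefore expected to show a small step, a 1.4-fold lower number from compound 1 to compound 4 (0.14 log units; within the scatter), downward if anything. For compound 4 the estimate is 900 nM, with a range from 350 nM to 2500 nM.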

Compound 4, concentration for 50% growth inhibition: 1190 nM
Compound 4: the middle estimate sits 1.3-fold (0.12 log units) below what was measured; low and high end bracket the measured number.
By their numbers in this assay, from the lowest: compounds 3, 4 and 1 (each within the scatter of the next); then compound 2.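

In this assay, trifluoromethyl in place of chloro on this aromatic carbon, turning the 3,4-dichlorophenyl group into 4-chloro-3-(trifluoromethyl)phenyl, gives a 1.0-fold lower number from compound 1 to compound 4 (0.02 log units; within the scatter). Going by these compounds alone, this is the first step on the urea aryl ring that changes one place only, and it shows that the two groups cannot be told apart at this position in this assay, even though trifluoromethyl has 4 heavy atoms where chloro has 1. Nothing measured here offers an explanation for this result.

Still open, on these data alone, is whether a different group at this position, such as a methyl, a nitrile or an amine, would move the number beyond the scatter. Also open, as far as these compounds go, is whether the same swap would leave the number just as unmoved on a compound carrying a hydroxyl in place of the methoxy group at the other end of the molecule.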